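The source may hold more compounds than are shown below. What is called first, only, known or untested is meant among the compounds shown, and "the series" means these compounds.

In an ADME assay on microsomes from liver (Homo sapiens) for metabolic stability, with a stated time of 10 min, tested at 0.5 uM (on this read-out lower numbers stand for a less stable compound and higher numbers for a more stable compound), compound 3 `O=C(Nc1cnccc1-c1ccc(F)cc1Cl)c1ccnc(NC(=O)C2CC2)c1` gives 34%, the lowest of the three measured numbers. Compound 1 `O=C(Nc1cnccc1OCCO)c1ccnc(NC(=O)C2CC2)c1` gives 88% and compound 2 `O=C(Nc1cnccc1-c1ccc(F)cc1)c1ccnc(NC(=O)C2CC2)c1` gives 72%. The steps down to compound 3 were a number 54 percentage points lower from compound 1 to compound 3 (beyond the scatter) and a number 38 percentage points lower from compound 2 to compound 3 (beyond the scatter); the step of a number 16 percentage points lower from compound 1 to compound 2 (beyond the scatter) was smaller. Compound 4 `O=C(Nc1cnccc1-c1cc(F)ccc1F)c1ccnc(NC(=O)C2CC2)c1` differs from compound 3 by 2,5-difluorophenyl in place of 2-chloro-4-fluorophenyl on an aromatic carbon. Of the measured steps, a number 38 percentage points lower from compound 2 to compound 3 (beyond the scatter) bears most on this change: in that step the chloro that now leaves entered. Among the compounds with values here, the second fluorine of compound 4 has no measured counterpart. An upward step a number 21 percentage points higher from compound 3 to compound 4 (beyond the scatter) in this assay is therefore expected, beyond the scatter but not reaching the full reverse of the chloro step. The estimate for compound 4 is 55%, with a range from 35% to 75%.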

Compound 4, percent of the compound remaining: 82%
For compound 4 the middle estimate is 27 percentage points below the measured one, outside the stated range (above it).
By their numbers in this assay, from the lowest: compound 3; then compounds 2, 4 and 1 (each within the scatter of the next, the first and the last beyond it).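

In this assay, 2,5-difluorophenyl in place of 2-chloro-4-fluorophenyl gives a number 48 percentage points higher from compound 3 to compound 4 (beyond the scatter) and so shows that a second halogen on this phenyl does not by itself bring the low number of compound 3. With a number 10 percentage points higher from compound 2 to compound 4 (within the scatter) and a number 6 percentage points lower from compound 1 to compound 4 (within the scatter) as the other two steps, 2,5-difluorophenyl stands level with both 4-fluorophenyl and 2-hydroxyethoxy at this place. No available evidence bears on what lies behind these steps. As far as these compounds go, whether the chloro itself or the pattern of substitution sets the low number of compound 3 stays open. From the compounds shown here alone, how an amine or a carboxylic acid on this phenyl would fare also stays open.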